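The source may hold more compounds than are shown below. What is called first, only, known or untested is meant among the compounds shown, and "the series" means these compounds.

Of the compounds shown here, three built on one shared core have been tested in a functional assay on MCF7 cells (Homo sapiens) for cytotoxicity, read by MTT assay, with a stated time of 72 h; a lower number here means a stronger inhibitor, a higher number a weaker inhibitor. Compound 1 `NC(=O)N1CCN(C(=S)SCc2cn(Cc3ccc(F)cc3)nn2)CC1` gives 22100 nM in this assay. Compound 2 `CCNC(=O)N1CCN(C(=S)SCc2cn(Cc3ccc(Cl)cc3)nn2)CC1` reaches only a limit of this assay, > 128000 nM, which is not a number. Compound 3 `COc1cc(Cn2cc(CSC(=S)N3CCN(C(N)=O)CC3)nn2)cc(OC)c1OC` likewise sits at a limit of this assay, > 128000 nM, so no number is known for it. The same limit holds two of the three values shown (the limit of > 128000 nM in this assay, at which 2 of the 3 values shown sit). Compound 4 `CCN(C)C(=O)N1CCN(C(=S)SCc2cn(Cc3cc(OC)c(OC)c(OC)c3)nn2)CC1` differs from compound 3 in one place: ethyl(methyl)amino in place of amino on a carbonyl carbon. Within the data shown here, no measured pair shows this change on its own, so its effect is open. Compound 4 is expected to stay at or near the limit, with a step that the limit leaves unreadable from compound 3 to compound 4 that need not exceed the scatter. The estimate for compound 4 is 150000 nM, between 50000 nM and 500000 nM.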

Compound 4, half-maximal inhibitory concentration: 68500 nM
Compound 4: the middle estimate sits 2.2-fold (0.34 log units) above what was measured, within the range that was stated.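

In this assay, placing ethyl(methyl)amino instead of amino on this carbonyl carbon gives an at least 1.8-fold lower number from compound 3 to compound 4 (0.27 log units; that floor lies within the scatter). This substitution therefore yields a measurable value here, although the step's floor alone does not establish a real change. The upper limit still blocks a full reading of the step: the limit of > 128000 nM in this assay, at which 2 of the 4 values shown sit.

The compounds shown leave open whether dimethylamino or a longer chain such as butylamino on the same carbonyl carbon would give a lower number. They also leave open whether ethyl(methyl)amino would have a similar effect on the core of compound 1.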